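A few compounds are considered here, and "the series" means these few. Any claim that something is new, unique, unknown or untested is made for them only; others in the source may bear on it.

Of the compounds shown here, three of one shared core have been tested so far. Compound 1 `COc1ccc2oc(-c3cn4nc(OC)sc4n3)cc2c1` carries a methoxy group on the benzofused ring and nothing more. In an assay on a cell-free system (plasma) for antagonist activity at proteinase-activated receptor 4 (Homo sapiens), with a stated time of 5 min, in the presence of a further agent that is not named here (a higher number here means a weaker inhibitor, a lower number a stronger inhibitor), compound 1 reaches only a limit, > 30000 nM, and no number is known for it. Compound 2 `COc1cc(OCc2ccccc2OC)c2cc(-c3cn4nc(OC)sc4n3)oc2c1` adds a benzyloxy group bearing a methoxy group. In this assay compound 2 also sits at a limit, > 1000 nM, so its inhibition is known only to lie beyond that point. For the measured compounds named here, compound 3 `COc1cc(OCc2cccc(COc3ccccc3)c2)c2cc(-c3cn4nc(OC)sc4n3)oc2c1` instead carries a benzyloxy group bearing a phenoxymethyl group, and in this assay compound 3 gives 600 nM, the only true number among the three.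

Compound 4 `COc1cc(OCc2ccccc2OCc2ccccc2)c2cc(-c3cn4nc(OC)sc4n3)oc2c1` is the next compound to be measured. It differs from compound 2 by phenyl in place of hydrogen on a saturated chain carbon bound to an oxygen on an aromatic ring. Going by the values given here, since compound 2 stands only at a limit, the step cannot be placed on a measured scale, and no step between measured compounds exists to guide the size. Given that compound 3, with a second aromatic ring reaching further out, gives 600 nM, compound 4 is expected to move toward stronger inhibition, by roughly a step that the limit leaves unreadable from compound 2 to compound 4. Compound 4 is therefore estimated at 1500 nM, within a range from 400 nM to 6000 nM.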

Compound 4, half-maximal inhibitory concentration: 2500 nM
Estimate against measurement, compound 4: 1.7-fold (0.22 log units) below; the range from low to high includes it.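

The step between compound 2 and compound 4 cannot be read, because compound 2 stands at a limit and not at a number: the limit of > 1000 nM in this assay, at which 1 of the 4 values shown sits. The compounds shown leave open how far phenyl in place of hydrogen on a saturated chain carbon bound to an oxygen on an aromatic ring shifts inhibition in this assay.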